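Notes on the step from compound 1 to compound 3

The compounds below may be only part of what the source reports. "The series", "measured", "known", "first", "only" and "open" are said of these compounds alone.

- compound 1 `O=C(CCCC(=O)Nc1ccc(NC(=O)Nc2ccc(Cl)c(C(F)(F)F)c2)cc1)NO`: > 10000 nM
- compound 2 `O=C(/C=C/c1ccc(NC(=O)Nc2ccc(Cl)c(C(F)(F)F)c2)cc1)NO`: 3200 nM
- compound 3 `O=C(Nc1ccc(NCc2ccc(C(=O)NO)cc2)cc1)Nc1ccc(Cl)c(C(F)(F)F)c1`: not yet measured

In a functional assay on SK-HEP1 cells (Homo sapiens) for inhibition, read by sulforhodamine B assay, with a stated time of 48 h (a higher number here means a weaker inhibitor, a lower number a stronger inhibitor), compound 1 gives > 10000 nM, which is a limit and not a number. Compound 3 carries 4-(hydroxycarbamoyl)benzyl in place of (3-(hydroxycarbamoyl)propyl)carbonyl on a nitrogen on an aromatic ring. Among the measured compounds shown here, the one measured step that bears on this is an at least 3.1-fold lower number from compound 1 to compound 2 (0.49 log units; beyond the scatter), which also replaces that chain. A step of similar size towards a lower number is therefore expected in this assay. The expected step is an at least 3.3-fold lower number from compound 1 to compound 3 (0.52 log units; beyond the scatter). The estimate for compound 3 is 3000 nM, with an expected range of 800 nM to 10000 nM.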

Compound 3, half-maximal inhibitory concentration: 7200 nM
Estimate against measurement, compound 3: 2.4-fold (0.38 log units) below; the measured number falls inside the stated range.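

Compound 1 gives > 10000 nM in this assay, which is a limit and not a number. With 4-(hydroxycarbamoyl)benzyl on the nitrogen, compound 3 gives a measured value of 7200 nM, so a chain holding a six-membered aromatic ring still leaves a readable number at this position. The step is an at least 1.3-fold lower number from compound 1 to compound 3 (0.14 log units; that floor lies within the scatter), so this change is not shown to lower the number beyond the scatter, and its true size stays hidden: the limit of > 10000 nM in this assay, at which 1 of the 3 values shown sits.

Open, going by these compounds, is whether the hydroxycarbamoyl itself is needed on the benzyl. A carboxylic acid in its place would address that.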